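The source may hold more compounds than are shown below. What is called first, only, known or untested is meant among the compounds shown, and "the series" means these compounds.

The measured compounds:
Compound 1 `CN(CCNCc1cn(-c2ccc(F)cc2)nn1)CCNc1ccnc2cc(Cl)ccc12` gives 12000 nM in a functional assay on BXPC-3 cells (Homo sapiens) for antiproliferative activity, read by sulforhodamine B assay, with a stated time of 72 h; a higher number here means a weaker inhibitor, a lower number a stronger inhibitor.
Compound 2 `CN(CCNCc1cn(-c2ccccc2Cl)nn1)CCNc1ccnc2cc(Cl)ccc12` gives 11000 nM in this assay.
Compound 3 `CN(CCNCc1cn(Cc2ccccc2)nn1)CCNc1ccnc2cc(Cl)ccc12` gives 9700 nM in this assay.

Compound 3 carries the lowest of the three numbers, yet its gaps to compound 2 and to compound 1 both lie within the scatter, so the three stand level. The change to compound 4 `CN(CCNCc1cn(-c2ccnc3cc(Cl)ccc23)nn1)CCNc1ccnc2cc(Cl)ccc12` is 7-chloroquinolin-4-yl in place of benzyl on an aromatic nitrogen. The steps that touch this same place, a 1.1-fold lower number from compound 1 to compound 2 (0.04 log units; within the scatter), a 1.2-fold lower number from compound 1 to compound 3 (0.09 log units; within the scatter) and a 1.1-fold lower number from compound 2 to compound 3 (0.05 log units; within the scatter), all stayed within the scatter when one aromatic group replaced another there. The entering group is larger than any tried so far, so one expects no step beyond the scatter in this assay, with a wider range to allow for the untried size. Compound 4 is therefore estimated at 9000 nM, between 3000 nM and 27000 nM, an expected step of a 1.1-fold lower number from compound 3 to compound 4 (0.03 log units; within the scatter).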

Compound 4, half-maximal inhibitory concentration: 8800 nM
Beside the measured number, compound 4's estimate is 1.0-fold (0.01 log units) above it; the range from low to high includes it.
By their numbers in this assay, from the lowest: compounds 4, 3, 2 and 1 (each within the scatter of the next).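

In this assay, the 7-chloroquinolin-4-yl group, larger than any earlier group and the first here to bring a ring nitrogen to this place, leaves the number level with the others: a 1.1-fold lower number from compound 3 to compound 4 (0.04 log units; within the scatter), a 1.3-fold lower number from compound 2 to compound 4 (0.10 log units; within the scatter) and a 1.4-fold lower number from compound 1 to compound 4 (0.13 log units; within the scatter). Across these four compounds, then, the size of the group on this aromatic nitrogen has shown no step beyond the scatter. Nothing available here bears on why the numbers stay level.

On these data alone, whether an amine, a carboxylic acid or a longer alkyl chain at this place would shift the number stays open. So does whether a change elsewhere in the shared core would.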